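Lengthening the Amine Side Chain: What to Expect

The source may hold more compounds than are shown below. What is called first, only, known or untested is meant among the compounds shown, and "the series" means these compounds.

Compound 1, `CN(C)CCN1CCN(CC(=O)Nc2ccc(-c3nc4cc(Cl)ccc4o3)cc2)CC1`: 2640 nM
Compound 2, `CN(C)CCN1CCN(CC(=O)Nc2ccc(-c3nc4ccccc4o3)cc2)CC1`: 16300 nM
Compound 3, `Cc1cc(-c2nc3cc(Cl)ccc3o2)ccc1NC(=O)CN1CCN(CCN(C)C)CC1`: 3880 nM

These three compounds were measured in a functional assay on HepG2 cells (Homo sapiens) for cytotoxicity, read by MTT assay, with a stated time of 24 h; a higher number here means a weaker inhibitor, a lower number a stronger inhibitor. Compound 1 has the lowest number shown. Compound 3 lies nearest, and the step of a 1.5-fold higher number from compound 1 to compound 3 (0.17 log units; within the scatter) stays within the scatter, so the two cannot be told apart. Compound 2 lies furthest, and the step of a 6.2-fold higher number from compound 1 to compound 2 (0.79 log units; beyond the scatter) is beyond the scatter.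

Compound 4, `CN(C)CCCN1CCN(CC(=O)Nc2ccc(-c3nc4cc(Cl)ccc4o3)cc2)CC1`, differs from compound 1 by (dimethylamino)methyl in place of dimethylamino on a saturated chain carbon, two bonds along the chain from an amine nitrogen in a ring. Neither measured step touches this chain: one removes a chloro, the other adds a methyl, both on aromatic carbons. With nothing bearing on the change, no step beyond the scatter is expected, a 1.1-fold higher number from compound 1 to compound 4 (0.06 log units; within the scatter). Compound 4 is therefore estimated at 3000 nM, with a range from 1000 nM to 9000 nM.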

Compound 4, half-maximal inhibitory concentration: 1250 nM
For compound 4 the middle estimate is 2.4-fold (0.38 log units) above the measured one; the range from low to high includes it.
By their numbers in this assay, from the lowest: compound 4; then compounds 1 and 3 (each within the scatter of the next); then compound 2.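

Lengthening the side chain from 2-(dimethylamino)ethyl to 3-(dimethylamino)propyl gives a 2.1-fold lower number from compound 1 to compound 4 (0.32 log units; beyond the scatter) in this assay. Among the compounds shown here, this chain, untouched by the earlier steps, therefore does affect the read-out, though the step is modest. Nothing measured here explains the shift.

Two chain lengths cannot establish a trend, so a longer chain such as 4-(dimethylamino)butyl could lower the number further or raise it again. As far as these compounds go, it also remains open whether the 3-(dimethylamino)propyl chain lowers the number without the chloro, or alongside the methyl of compound 3.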